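The source may hold more compounds than are shown below. What is called first, only, known or untested is meant among the compounds shown, and "the series" means these compounds.

Measured compounds in a functional assay on the whole organism (strain albino) for inhibition, with Rattus norvegicus as the target, read by paw edema, with stated times of 30 min and 3 h, at a dose of 100 mg/kg by the oral route; a lower number here means less inhibition, a higher number more inhibition at the dose given (going by the name of the read-out):
- compound 1 `COc1ccc(C2=NNC(c3ccco3)C2)cc1OC` gives 60%
- compound 2 `COc1ccc(C2=NNC(c3c(Cl)cccc3Cl)C2)cc1OC` gives 58%
- compound 3 `COc1ccc(C2=NN(C(=O)C(C)Br)C(c3c(Cl)cccc3Cl)C2)cc1OC` gives 60%

Compound 1 stands level with compound 3 at the digits printed, the two together the highest of the three numbers; compound 2 sits within the scatter of both. The unmeasured compound 4 `COc1ccc(C2=NN(C(=O)C(C)O[N+](=O)[O-])C(c3ccco3)C2)cc1OC` differs from compound 1 by a group of 8 heavy atoms (3 carbon, 1 nitrogen, 4 oxygen; no ring) in place of a hydrogen atom, on an amine nitrogen in a ring. Among the compounds with values here, the only measured step of comparable kind, a (1-bromoethyl)carbonyl in place of hydrogen on an amine nitrogen in a ring, is a number 2 percentage points higher from compound 2 to compound 3 (within the scatter) and lay within the scatter. The step to compound 4 is therefore expected to be no change at the digits printed from compound 1 to compound 4 (within the scatter), nothing beyond the scatter. Compound 4 is estimated at 60%, with a range from 50% to 70%.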

Compound 4, a percentage reported as inhibition, in the whole organism at one dose (the size of the read-out at that dose, not a potency): 42%
Beside the measured number, compound 4's estimate is 18 percentage points above it; the measured number lies below the stated range.
By their numbers in this assay, from the lowest: compound 4; then compounds 2, 1 and 3 (each within the scatter of the next).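

Within the data shown here, on the amine nitrogen in a ring, substitution is not neutral in every case: in this assay the group of 8 heavy atoms gives a number 18 percentage points lower from compound 1 to compound 4 (beyond the scatter), the first step beyond the scatter. The earlier step, a number 2 percentage points higher from compound 2 to compound 3 (within the scatter), differs in both the entering group and the rest of the molecule, so the two steps do not isolate a single change. No measurement shown explains the lower number.

Still open, from the compounds shown here alone, is how a simple acetyl group on this nitrogen would read with the furan-2-yl group in place. A hydroxyl group at the end of the same chain would help show whether the fall follows the nitrate ester or the acyl chain.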